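A Tetrahydroisoquinoline in Place of a Methylpiperidine

The compounds below may be only part of what the source reports. "The series", "measured", "known", "first", "only" and "open" are said of these compounds alone.

Of the compounds shown here, three have been measured in a physicochemical assay for solubility, read by spectrophotometry, in phosphate buffer, with a stated time of 2 h, at pH 7.4; on this read-out higher numbers stand for higher solubility and lower numbers for lower solubility. Compound 2 `COc1ccc2[nH]c(C(=O)N3CC(=O)N(Cc4ccccc4)[C@@H](CN4CCC(C)CC4)C3)cc2c1` stands highest of the three, giving 93100 nM. In this assay compound 3 `COc1ccc2[nH]c(C(=O)N3CC(=O)N(Cc4c[nH]c5ccccc45)[C@@H](Cc4ccccc4)C3)cc2c1` gives 10300 nM and compound 1 `COc1cccc(CN2C(=O)CN(C(=O)c3cc4cc(OC)ccc4o3)C[C@@H]2CCc2ccccc2)c1` gives 4900 nM, and both of these gaps to compound 2 lie beyond the scatter. No pair of these compounds differs in only one place, so no measured step is available to guide the next compound. Compound 4 `COc1ccc2[nH]c(C(=O)N3CC(=O)N(Cc4ccccc4)[C@@H](CN4CCc5ccccc5C4)C3)cc2c1` differs from compound 2 in one place: 1,2,3,4-tetrahydroisoquinolin-2-yl in place of 4-methylpiperidin-1-yl on a saturated chain carbon bound to a saturated ring carbon. Among the measured compounds shown here, with no measured precedent, the step from compound 2 to compound 4 is expected to run downward and beyond the scatter, at an estimated 3.7-fold lower number from compound 2 to compound 4 (0.57 log units; beyond the scatter). Compound 4 is therefore expected to give about 25000 nM in this assay, within a range from 8000 nM to 75000 nM.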

Compound 4, solubility: 9000 nM
Compound 4: middle estimate off by 2.8-fold (0.44 log units), on the high side, within the range that was stated.
By their numbers in this assay, from the lowest: compounds 1, 4 and 3 (each within the scatter of the next, the first and the last beyond it); then compound 2.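

Among the compounds shown here, replacing 4-methylpiperidin-1-yl with 1,2,3,4-tetrahydroisoquinolin-2-yl gives the first measured step in this set: in this assay, it brings a 10-fold lower number from compound 2 to compound 4 (1.01 log units; beyond the scatter). The read-out at this position therefore responds strongly to the group carried there, although the two groups have the same counts of hydrogen-bond donors and acceptors and neither has a net charge. Nothing available explains the drop. The compounds shown leave open whether the added aromatic ring accounts for the step. They also leave open how a morpholine or a carboxylic acid at this position would read.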